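Series notes: ester and nitrogen substituent on the shared core

The source may report more compounds than this note shows. Statements on the series, on what has been measured and on what is new or still open speak of the compounds shown alone.

Compound 1 `CC(=O)Oc1ccc2c(c1)C(C)=CC(C)(C)N2Cc1ccccc1` is the reference. In an ADME assay on L6 cells (Rattus norvegicus) for cytotoxicity, read by resazurin assay, with a stated time of 70 h (on this read-out higher numbers stand for weaker inhibition and lower numbers for stronger inhibition), compound 1 gives 24000 nM. Compound 2 `COc1cc(OC)cc(C(=O)Oc2ccc3c(c2)C(C)=CC(C)(C)N3Cc2ccccc2)c1` gives 24000 nM in this assay, and the step of no change at the digits printed from compound 1 to compound 2 (within the scatter) is within the scatter. Compound 3 `CC1=CC(C)(C)N(Cc2ccccc2)c2ccc(OC(=O)C3CCCCC3)cc21` reaches only the limit > 230000 nM in this assay, and that limit is the limit of > 230000 nM in this assay, at which 1 of the 3 values shown sits. The steps of an at least 9.5-fold higher number from compound 1 to compound 3 (0.98 log units; beyond the scatter) and an at least 9.5-fold higher number from compound 2 to compound 3 (0.98 log units; beyond the scatter) both move beyond the scatter.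

Compound 4 `CC(=O)Oc1ccc2c(c1)C(C)=CC(C)(C)N2C` differs from compound 1 at another place: hydrogen in place of phenyl on a saturated chain carbon bound to a nitrogen on an aromatic ring in a ring. Within the data shown here, none of the measured steps touches this position; all three vary the group on the carbonyl carbon. The step expected for compound 4 is therefore a 1.3-fold higher number from compound 1 to compound 4 (0.10 log units; within the scatter), none beyond the scatter. Compound 4 is estimated at 30000 nM in this assay, within 12000 nM to 120000 nM.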

Compound 4, half-maximal inhibitory concentration: 41000 nM
Compound 4: the middle estimate sits 1.4-fold (0.14 log units) below what was measured; the range from low to high includes it.
By their numbers in this assay, from the lowest: compounds 1, 2 and 4 (each within the scatter of the next). At a limit, above all of these: compound 3.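

The change from benzyl to methyl is the first shown away from the carbonyl carbon, and a 1.7-fold higher number from compound 1 to compound 4 (0.23 log units; within the scatter) in this assay. The phenyl of compound 1 can therefore be lost at this place without a step beyond the scatter, unlike the change to cyclohexyl on the carbonyl carbon. Nothing shown bears on the cause of this small step.

Open, as far as these compounds go, is how a longer chain or an amine would read at this place. Also open, from the compounds shown here alone, is whether methyl in place of benzyl would leave the limit of compound 3 in place.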